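Pyridin-4-yl for phenyl on a shared fused core

The source may report more compounds than this note shows. Statements on the series, on what has been measured and on what is new or still open speak of the compounds shown alone.

Measured compounds in a functional assay on Pfeiffer cells (Homo sapiens) for inhibition, read by CCK-8 assay; on this read-out higher numbers stand for weaker inhibition of growth and lower numbers for stronger inhibition of growth:
- compound 1 `O=S(=O)(Nc1cc(-c2cnc3[nH]cc(-c4ccncc4)c3c2)cnc1Cl)c1ccccc1F`: 290 nM
- compound 2 `O=S(=O)(Nc1cc(-c2cnc3[nH]nc(-c4ccccc4)c3c2)cnc1Cl)c1ccccc1`: 1300 nM
- compound 3 `O=S(=O)(Nc1cc(-c2cnc3[nH]cc(-c4ccccc4)c3c2)cnc1Cl)c1ccccc1`: 1520 nM

Compound 3 gives the highest number of the three in this assay. Its nearest neighbour is compound 2, whose number lies within the usual scatter of that of compound 3, so the two cannot be told apart here. Compound 1 stands furthest away, with a number beyond the scatter and on the lower side of compound 3.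

The step under consideration leads from compound 3 to compound 4 `O=S(=O)(Nc1cc(-c2cnc3[nH]cc(-c4ccncc4)c3c2)cnc1Cl)c1ccccc1`, a compound not yet measured. The change is pyridin-4-yl in place of phenyl on an aromatic carbon. Among the compounds with values here, no other pair in this set differs in just this one place, so there is no measured step of the same kind to lean on. Compound 1, however, carries the same pyridin-4-yl group and gives 290 nM, while compound 3 with phenyl gives 1520 nM; the two differ elsewhere as well, so only their values can be set side by side.

On that basis the number for compound 4 in this assay is expected to fall, with the step of a 3.4-fold lower number from compound 3 to compound 4 (0.53 log units; beyond the scatter) lying beyond the scatter. The estimate for compound 4 is 450 nM, with a range from 200 nM to 1000 nM.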

Compound 4, concentration for 50% growth inhibition: 100 nM
Compound 4: middle estimate off by 4.5-fold (0.65 log units), on the high side; the whole stated range lies above it.
By their numbers in this assay, from the lowest: compound 4; then compound 1; then compounds 2 and 3 (each within the scatter of the next).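

In this assay, within the data shown here, the step of a 15-fold lower number from compound 3 to compound 4 (1.18 log units; beyond the scatter) is the first direct reading of pyridin-4-yl in place of phenyl on an aromatic carbon of the five-membered aromatic ring, and it shows that this one change, with the rest of the molecule held constant, is large at this position. With pyridin-4-yl present in both compounds, the step of a 2.9-fold lower number from compound 1 to compound 4 (0.46 log units; beyond the scatter) for hydrogen in place of fluoro shows that the low number of compound 4 does not depend on the fluoro group, which compound 4 lacks. Nothing given here accounts for either step.

The compounds shown leave open whether the ring nitrogen must stand where it does in pyridin-4-yl, since neither pyridin-3-yl, pyridin-2-yl nor a saturated ring such as piperidin-4-yl appears at this position. They also leave open whether pyridin-4-yl in place of phenyl would give a step of similar size on the core of compound 2, or with a substituent such as a methyl or an amine on the pyridine ring.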